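This account rests on a few compounds, and the source may have more. Where it says the series, first, only, none or still open, it means among the compounds named here.

Compound 3 `COc1ccc(-c2ccc(OCc3cc(C(=O)NS(=O)(=O)c4c(C)noc4C)oc3C)cc2)c(C)c1` gives 24 nM in an assay on cells for displacement of a labelled ligand from prostaglandin E2 receptor EP4 subtype (Homo sapiens), read by scintillation counting (a lower number here means a stronger inhibitor, a higher number a weaker inhibitor), the highest of the three numbers measured. Compound 1 `COc1ccc(-c2ccc(OCc3cc(C(=O)NS(=O)(=O)c4ccccc4)oc3C)cc2)c(C)c1` gives 21 nM, and the step of a 1.1-fold higher number from compound 1 to compound 3 (0.06 log units; within the scatter) lies within the scatter. Compound 2 `COc1ccc(-c2ccc(OCc3cc(C(=O)NS(=O)(=O)c4cccs4)oc3C)cc2)cc1` gives 3.6 nM, a lower number beyond the scatter, but it differs from compound 3 in two places at once. Compound 4 `Cc1noc(C)c1S(=O)(=O)NC(=O)c1cc(COc2ccc(-c3ccc(OC(F)F)cc3)cc2)c(C)o1` carries the change (4-(difluoromethoxy)phenyl in place of 4-methoxy-2-methylphenyl on an aromatic carbon). Going by the values given here, no measured step touches this end of the molecule, so the size and direction of the move are open; the one measured step concerns the sulfonyl group only. An expectation near the current number seems most defensible, so compound 4 is expected to give 20 nM, between 6 nM and 65 nM, a step of a 1.2-fold lower number from compound 3 to compound 4 (0.08 log units; within the scatter) from compound 3.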

Compound 4, inhibition constant: 0.6 nM
For compound 4 the middle estimate is 33-fold (1.52 log units) above the measured one; the whole stated range lies above it.
By their numbers in this assay, from the lowest: compound 4; then compound 2; then compounds 1 and 3 (each within the scatter of the next).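

In this assay replacing 4-methoxy-2-methylphenyl with 4-(difluoromethoxy)phenyl gives a 40-fold lower number from compound 3 to compound 4 (1.60 log units; beyond the scatter) and so shows that this end of the molecule can move the number strongly, which the sulfonyl step alone gave no sign of. No measurement here offers an explanation for the size of this move. The change alters two features at once, removing the ring methyl and turning methoxy into difluoromethoxy, and the compounds shown do not separate the two. As far as these compounds go, how a trifluoromethoxy group or a chlorine atom in that place would read also stays open.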